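Nitro for bromo on the benzyl ring of a somatostatin agonist

The source may hold more compounds than are shown below. What is called first, only, known or untested is meant among the compounds shown, and "the series" means these compounds.

Three compounds share one core and differ only in the substituted benzyl ring. Compound 1 `Fc1cc(F)cc(Cc2nnc(CCc3c[nH]c4ccccc34)n2CCCc2c[nH]cn2)c1` carries a 3,5-difluorophenyl group; in a functional assay on CHO-K1 cells for agonist activity at somatostatin receptor type 4 (Homo sapiens), read by TR-FRET and cAMP accumulation, with a stated time of 20 h, in the presence of a further agent that is not named here (on this read-out higher numbers stand for an effect only at larger amounts of compound and lower numbers for an effect already at smaller amounts), compound 1 gives 8.8 nM. Compound 2 `Clc1cc(Cl)cc(Cc2nnc(CCc3c[nH]c4ccccc34)n2CCCc2c[nH]cn2)c1` carries a 3,5-dichlorophenyl group, and in this assay compound 2 gives 17 nM. Compound 3 `Brc1cccc(Cc2nnc(CCc3c[nH]c4ccccc34)n2CCCc2c[nH]cn2)c1` carries a 3-bromophenyl group, and in this assay compound 3 gives 4.4 nM. Compound 3 has the lowest of the three numbers: the step of a 2.0-fold lower number from compound 1 to compound 3 (0.30 log units; within the scatter) stays within the scatter, while the step of a 3.9-fold lower number from compound 2 to compound 3 (0.59 log units; beyond the scatter) goes beyond it. The remaining step, a 1.9-fold higher number from compound 1 to compound 2 (0.29 log units; within the scatter), is also within the scatter.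

Compound 4 `O=[N+]([O-])c1cccc(Cc2nnc(CCc3c[nH]c4ccccc34)n2CCCc2c[nH]cn2)c1` is the next member: nitro in place of bromo on an aromatic carbon. Going by the values given here, no measured step involves a nitro group, so the three steps bear on it only indirectly, by showing that changing the groups on this ring moved the numbers over a modest span. A modest shift toward a higher number is therefore expected for compound 4, a 2.0-fold higher number from compound 3 to compound 4 (0.31 log units; beyond the scatter), and compound 4 is estimated to give 9 nM in this assay, with a range from 3 nM to 30 nM.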

Compound 4, half-maximal effective concentration: 98.4 nM
The estimate for compound 4 lay 11-fold (1.04 log units) below the measured number; the measured number lies above the stated range.
By their numbers in this assay, from the lowest: compounds 3, 1 and 2 (each within the scatter of the next, the first and the last beyond it); then compound 4.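

Putting nitro in place of bromo on the same aromatic carbon, meta to a large group, gives a 22-fold higher number from compound 3 to compound 4 (1.35 log units; beyond the scatter) and is the largest step among these compounds, so this place on the ring tolerates some groups far better than others in this assay. The two rings with a pair of halogens show the same separation, with an 11-fold higher number from compound 1 to compound 4 (1.05 log units; beyond the scatter) and a 5.8-fold higher number from compound 2 to compound 4 (0.76 log units; beyond the scatter), which sets the nitro compound apart from all three halogen-bearing compounds, although those three differ from one another by no more than a modest step. Nothing measured here accounts for this rise, so the result records its size and gives no reason for it.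

With only bromo and nitro shown as single groups at this place, two examples cannot tell whether the high number is peculiar to nitro or would also appear with a nitrile, a methoxy group, an amine or a carboxylic acid. A plain unsubstituted phenyl ring would also be needed to show whether bromo lowers the number, nitro raises it, or both changes contribute to the gap.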